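The source may hold more compounds than are shown below. What is called first, only, known or untested is meant among the compounds shown, and "the series" means these compounds.

Measured so far in a functional assay on U-87MG ATCC cells (Homo sapiens) for cytotoxicity, read by MTT assay, with a stated time of 72 h; on this read-out higher numbers stand for weaker inhibition and lower numbers for stronger inhibition:
- compound 1 `CN(C)CCn1cnnc1-c1cc(Oc2ccc(NC(=O)N/N=C/c3cc(C(C)(C)C)cc(C(C)(C)C)c3O)cc2F)ccn1`: 520 nM
- compound 2 `CN(C)CCn1cnnc1-c1cc(Oc2ccc(NC(=O)N/N=C/c3ccc(O)cc3)cc2F)ccn1`: 7750 nM
- compound 3 `CN(C)CCn1cnnc1-c1cc(Oc2ccc(NC(=O)N/N=C/c3cc(Br)c(O)c(Br)c3)cc2F)ccn1`: a limit of the assay, > 100000 nM

Compound 2 stands highest of the two numbers in this assay; its nearest neighbour is compound 1, which sits well below it, beyond the scatter. Compound 3 reports only a limit and no number, the limit described as the limit of > 100000 nM in this assay, at which 1 of the 3 values shown sits. For the measured compounds named here, the one measured step at the ring on the carbon with a double bond to nitrogen, an at least 12-fold higher number from compound 2 to compound 3 (1.11 log units; beyond the scatter), is large and goes toward weaker inhibition. Compound 1 and compound 2 differ in the same region, and their two values show the tert-butyl-bearing hydroxyphenyl giving the stronger inhibition of the pair.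

Compound 4 `CN(C)CCn1cnnc1-c1cc(Oc2ccc(NC(=O)N/N=C/c3ccc(F)cc3F)cc2F)ccn1` differs from compound 2 by 2,4-difluorophenyl in place of 4-hydroxyphenyl on a carbon with a double bond to nitrogen. Neither measured step substitutes the hydroxyl itself, so the comparison to compound 2 is indirect; the step to compound 3 shows that changes at this ring can cost a great deal, while compound 1 shows that this ring also tolerates substantial substitution. Against this, no strong move in either direction is expected, with a lean toward a somewhat higher number: for compound 4 the expected step is a 1.5-fold higher number from compound 2 to compound 4 (0.19 log units; within the scatter). In this assay compound 4 is estimated at 12000 nM, with a range from 2500 nM to 60000 nM.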

Compound 4, half-maximal inhibitory concentration: 1900 nM
Compound 4: middle estimate off by 6.3-fold (0.80 log units), on the high side; the measured number lies below the stated range.
By their numbers in this assay, from the lowest: compound 1; then compound 4; then compound 2. At a limit, above all of these: compound 3.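

In this assay, the hydroxyl of compound 2 is not needed for the read-out at this position: a 4.1-fold lower number from compound 2 to compound 4 (0.61 log units; beyond the scatter), with 2,4-difluorophenyl, carrying 0 hydrogen-bond donors, in place of 4-hydroxyphenyl, which carries 1. Halogen on this ring is also not tied to the loss seen earlier, as an at least 52-fold lower number from compound 3 to compound 4 (1.72 log units; beyond the scatter) when 2,4-difluorophenyl replaces 3,5-dibromo-4-hydroxyphenyl on the carbon with a double bond to nitrogen. The size of that second step has only a bound, as compound 3 is held at a limit and not at a number: the limit of > 100000 nM in this assay, at which 1 of the 4 values shown sits.

The compounds shown do not separate the loss of the hydroxyl from the arrival of the two fluorines, and a plain phenyl would bear directly on that question. On these data alone, it also stays open how a methoxy group or an amine on this ring would read in this assay, and whether the step to compound 4 would carry over to the differently substituted ring of compound 1.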